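Pyridyl hydrazide series: cytotoxicity working notes

The source may report more compounds than this note shows. Statements on the series, on what has been measured and on what is new or still open speak of the compounds shown alone.

Measured compounds:
- compound 1 `Cc1c(/C=N/NC(=O)c2ccncc2)no[n+]1[O-]`: > 400000 nM
- compound 2 `O=C(N/N=C/c1ccc2nonc2c1)c1cccnc1`: 209000 nM
- compound 3 `Cc1c(/C=N/NC(=O)c2cccnc2)no[n+]1[O-]`: > 400000 nM

Within the data shown here, in an ADME assay on J774.1 cells (Mus musculus) for cytotoxicity, read by MTT assay, with a stated time of 48 h (on this read-out higher numbers stand for weaker inhibition and lower numbers for stronger inhibition), compound 2 gives 209000 nM, the only true number among the three values. Compound 1 sits at a limit of the read-out, not a number. Compound 3 likewise sits at a limit and not a number, so both of these entries show only (the limit of > 400000 nM in this assay, at which 2 of the 3 values shown sit). The change from compound 3 to compound 1 is pyridin-4-yl in place of pyridin-3-yl on a carbonyl carbon; the step that the two limits leave unreadable from compound 3 to compound 1 cannot be sized because both ends are limits (the limit of > 400000 nM in this assay, at which 2 of the 3 values shown sit).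

Compound 4 `O=C(N/N=C/c1ccc2nonc2c1)c1ccncc1` has not yet been measured in this assay . It stands to compound 2 as compound 1 stands to compound 3: pyridin-4-yl in place of pyridin-3-yl on a carbonyl carbon, the same change at a place described in the same words. The difference between the core of compound 2 and the core of compound 3 is not broken down here.

From compound 2 to compound 4 the step in this assay is expected to be a 1.2-fold higher number from compound 2 to compound 4 (0.08 log units; within the scatter), close to flat. Among the measured compounds shown here, this rests on the measured step that the two limits leave unreadable from compound 3 to compound 1, which offers no readable size, and on compound 2 itself at 209000 nM being the only anchor with a number; the swap of pyridin-4-yl for pyridin-3-yl keeps the same atoms joined differently. Compound 4 is therefore estimated at 250000 nM, expected between 120000 nM and 450000 nM, with a real chance that the assay reports only a limit.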

Compound 4, half-maximal inhibitory concentration: > 400000 nM
Compound 4 ended at the assay's limit (the forecaster's own chance of this, stated with the estimate: 35%); at least 1.6-fold (0.20 log units) between middle value and limit.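

From the compounds shown here alone, on the core of compound 2, pyridin-4-yl in place of pyridin-3-yl on a carbonyl carbon gives an at least 1.9-fold higher number from compound 2 to compound 4 (0.28 log units; that floor lies within the scatter) in this assay, so the change does not lower the number on this core, although the floor of the step stays within the scatter and its true size remains unknown. Compound 4 gives > 400000 nM, which is a limit of the read-out and not a number. On the core of compound 3 the same change cannot be read, so the series offers no two sizes to compare, and the step neither confirms nor refutes that the change carries from one core to the other, with the read-out capped for most of the series: the limit of > 400000 nM in this assay, at which 3 of the 4 values shown sit.

Still open, going by these compounds, is how pyridin-2-yl or a plain phenyl group would read on the same carbonyl carbon on either core, and whether an amine or a carboxylic acid on the pyridyl group would give values short of the limit. Among these compounds, also open is how far the core of compound 2 and the core of compound 3 differ in their own right, since only one of these two compounds carries a true number.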